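The source may hold more compounds than are shown below. What is called first, only, known or untested is meant among the compounds shown, and "the series" means these compounds.

- Compound 1 `Cc1cccc(Cn2cc(COc3ccc4c(=O)ccoc4c3)nn2)c1`: 16000 nM
- Compound 2 `O=c1ccoc2cc(OCc3cn(Cc4ccc(Cl)cc4)nn3)ccc12`: > 100000 nM (a limit)
- Compound 3 `Cc1ccccc1Cn1cc(COc2ccc3c(=O)ccoc3c2)nn1`: > 100000 nM (a limit)

Among the compounds with values here, in a functional assay on MDA-MB-231 cells (Homo sapiens) for cytotoxicity, read by MTT assay, with a stated time of 48 h (on this read-out lower numbers stand for stronger inhibition and higher numbers for weaker inhibition), compound 1 gives 16000 nM, the only true number so far. The other two results are limits, as the limit of > 100000 nM in this assay, at which 2 of the 3 values shown sit, shows, so compound 1 stands at the low end of what has been measured.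

Compound 4 `O=c1ccoc2cc(OCc3cn(Cc4ccc(Cl)cc4Cl)nn3)ccc12` is not yet measured. It differs from compound 1 as follows: 2,4-dichlorophenyl in place of 3-methylphenyl on a saturated chain carbon bound to an aromatic nitrogen. In short, 3-methylbenzyl becomes 2,4-dichlorobenzyl.

Within the data shown here, two measured steps bear on this change. Replacing 3-methylphenyl with 4-chlorophenyl gives an at least 6.2-fold higher number from compound 1 to compound 2 (0.79 log units; beyond the scatter). Replacing it with 2-methylphenyl gives an at least 6.2-fold higher number from compound 1 to compound 3 (0.79 log units; beyond the scatter). Both are beyond the scatter and point the same way, though each gives only a lower bound on its size. A step of at least modest size towards a higher number is therefore expected in this assay. The expected step is a 5.6-fold higher number from compound 1 to compound 4 (0.75 log units; beyond the scatter). Compound 4 is estimated at 90000 nM, with an expected range of 25000 nM to 300000 nM.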

Compound 4, half-maximal inhibitory concentration: > 100000 nM
Compound 4: no number, only a limit; the forecaster's own chance of this, stated with the estimate: 60%; middle value at least 1.1-fold (0.04 log units) from the limit.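

In this assay, 2,4-dichlorobenzyl gives an at least 6.2-fold higher number from compound 1 to compound 4 (0.79 log units; beyond the scatter), so a third replacement of 3-methylbenzyl at this place ends in a limit and not a number. Among the four compounds, only compound 1 with its 3-methylbenzyl gives a true number, and neither chloro nor a shifted methyl group on the phenyl ring retains one: the limit of > 100000 nM in this assay, at which 3 of the 4 values shown sit. The steps among compounds 2, 3 and 4 join limits and cannot be read, so the added chloro on an aromatic carbon shows no effect of its own.

Going by these compounds, how far compounds 2, 3 and 4 lie past their limits remains open. Also open, on these data alone, is whether a methoxy group or an amine in place of the methyl of compound 1 would give a true number, and what a longer chain at this place would give.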